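The source may report more compounds than this note shows. Statements on the series, on what has been measured and on what is new or still open speak of the compounds shown alone.

Among the measured compounds shown here, in a functional assay on NCI-H460 cells (Homo sapiens) for inhibition, read by MTT assay, with a stated time of 48 h (a lower number here means a stronger inhibitor, a higher number a weaker inhibitor), compound 1 (`O=C(CC(c1ccc(F)cc1)C(C(=O)Nc1ccccn1)C(=O)Nc1ccccn1)c1ccc(F)cc1`) gives 20100 nM, the only number so far in this small set. Compound 2 (`O=C(CC(c1ccc([N+](=O)[O-])cc1)C(C(=O)Nc1ccccn1)C(=O)Nc1ccccn1)c1ccccc1`) is recorded as "not active" (no number reported), so it stands without a single number and cannot be placed on the scale against compound 1. Compound 3 (`Cc1cc(C)c(C(CC(=O)c2ccccc2)C(C(=O)Nc2ccccn2)C(=O)Nc2ccccn2)c(C)c1`) keeps the shared core of compound 2 and alters one group: 2,4,6-trimethylphenyl in place of 4-nitrophenyl on a saturated chain carbon bound to two saturated chain carbons. For the measured compounds named here, no measured pair of compounds differing in one place is available, so the size of this change has no direct precedent in the data. The step from compound 2 can therefore be expected only in broad terms: in this assay, the likeliest gain is a move from no reported number to weak inhibition, although a second "not active" result remains a real possibility. The nearest guide to a measurable result is compound 1 at 20100 nM, which suggests a reading in the same weak region rather than a strong inhibitor. Compound 3 is estimated at about 30000 nM, with an expected range from 10000 nM to 100000 nM.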

Compound 3, half-maximal inhibitory concentration: 23200 nM
Compound 3: the middle estimate sits 1.3-fold (0.11 log units) above what was measured; low and high end bracket the measured number.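

No step can be read for compound 3 in this assay: compound 2 has no number to set against it, and compound 1 differs from compound 3 in more than one place. No available evidence bears on this result. The compounds shown leave open what exchanging 4-nitrophenyl for 2,4,6-trimethylphenyl alone does to inhibition.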